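The source may hold more compounds than are shown below. What is called first, only, known or untested is meant among the compounds shown, and "the series" means these compounds.

Measured so far in a functional assay on SGC-7901 cells (Homo sapiens) for inhibition, read by MTT assay, with a stated time of 72 h; a higher number here means a weaker inhibitor of growth, a lower number a stronger inhibitor of growth:
Compound 1 `O=C1COc2ccc(-n3cc(C[C@H](O)COCCOC[C@@H](O)Cc4ccc(-c5ccccc5)cc4)nn3)cc2N1` gives 15200 nM.
Compound 2 `O[C@H](COCCOC[C@@H](O)Cc1cn(-c2ccc3c(c2)OCCO3)nn1)Cc1ccc(-c2ccccc2)cc1` gives 6400 nM.
Compound 3 `O[C@H](COCCOC[C@@H](O)Cc1cn(Cc2ccc3ccccc3c2)nn1)Cc1ccc(-c2ccccc2)cc1` gives 12100 nM.

Compound 3 stands second highest of the three numbers; the steps of a 1.3-fold lower number from compound 1 to compound 3 (0.10 log units; within the scatter) and a 1.9-fold higher number from compound 2 to compound 3 (0.28 log units; within the scatter) are both within the scatter, and only a 2.4-fold lower number from compound 1 to compound 2 (0.38 log units; beyond the scatter) is beyond it, as a modest step.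

Compound 4 `O[C@H](COCCOC[C@@H](O)Cc1c[nH]nn1)Cc1ccc(-c2ccccc2)cc1` is reached from compound 3 by hydrogen in place of (naphthalen-2-yl)methyl on an aromatic nitrogen. The steps bearing on it, a 1.3-fold lower number from compound 1 to compound 3 (0.10 log units; within the scatter) and a 1.9-fold higher number from compound 2 to compound 3 (0.28 log units; within the scatter), only exchange one group for another on that aromatic nitrogen and were small; none removes the group altogether, so the expectation is weakly grounded. A step toward a higher number, a 2.1-fold higher number from compound 3 to compound 4 (0.32 log units; beyond the scatter), is expected for compound 4, since the exchanged groups shifted the numbers little. Compound 4 is estimated at 25000 nM, range 8000 nM to 80000 nM.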

Compound 4, concentration for 50% growth inhibition: > 100000 nM
Compound 4: no number, only a limit; the forecaster's own chance of this, stated with the estimate: 25%; middle value at least 4.0-fold (0.60 log units) away from the limit.
By their numbers in this assay, from the lowest: compounds 2, 3 and 1 (each within the scatter of the next, the first and the last beyond it). At a limit, above all of these: compound 4.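

In this assay compound 4 is read only at a limit, not a number: the limit of > 100000 nM in this assay, at which 1 of the 4 values shown sits.

Exchanging one group for another on this aromatic nitrogen had moved the numbers only modestly at most, whereas hydrogen in place of the group gives an at least 8.2-fold higher number from compound 3 to compound 4 (0.91 log units; beyond the scatter), an at least 15-fold higher number from compound 2 to compound 4 (1.19 log units; beyond the scatter) and an at least 6.5-fold higher number from compound 1 to compound 4 (0.81 log units; beyond the scatter). Among the compounds shown, therefore, all three bearing a large group on this nitrogen give a measured number, and the one bearing hydrogen does not.

From the compounds shown here alone, the true size of these steps remains open, since they rest on a limit. Also open, going by these compounds, is whether a group as small as methyl, or a chain ending in an amine, would suffice on this nitrogen.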